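The compounds below may be only part of what the source reports. "The series", "measured", "known", "first", "only" and "open" are said of these compounds alone.

Measured so far:
- compound 1 `CO[C@]1(C)/C=C/C(=O)/C(CO)=C\C[C@](C)(CCC=C(C)C)/C=C/[C@H]1OC(=O)C=C(C)C` — 14300 nM
- compound 2 `CC(C)=CCC[C@]1(C)/C=C/[C@@H](OC(=O)C=C(C)C)[C@](C)(O)/C=C/C(=O)/C(CN(C)C)=C\C1` — 140 nM

In a functional assay on HL-60 cells (Homo sapiens) for antiproliferative activity, read by MTT assay, with a stated time of 48 h (a higher number here means a weaker inhibitor, a lower number a stronger inhibitor), compound 1 gives 14300 nM and compound 2 gives 140 nM. For the measured compounds named here, compound 2 stands at the lowest of the two numbers; the only neighbour is compound 1, whose number is far higher and clearly beyond the scatter. The two differ in more than one place, so nothing can be said about which of the differences carries the gap.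

Compound 3 `CO/N=C/C1=C/C[C@](C)(CCC=C(C)C)/C=C/[C@@H](OC(=O)C=C(C)C)[C@](C)(O)/C=C/C1=O` is not yet measured in this assay. Relative to compound 2 it changes as follows: a group of 4 heavy atoms (2 carbon, 1 nitrogen, 1 oxygen; no ring) in place of a group of 4 heavy atoms (3 carbon, 1 nitrogen; no ring), on a double-bonded ring carbon

Going by the values given here, no single-point step between measured compounds is available, so there is no precedent for this exchange. The group that enters carries one more hydrogen-bond acceptor than the one that leaves, and the series gives no measured guide to how such a swap plays out. A moderate shift toward weaker inhibition is expected, but one that could fall within the scatter. Compound 3 is expected to give about 400 nM in this assay, somewhere between 100 nM and 2500 nM, which would be a step of a 2.9-fold higher number from compound 2 to compound 3 (0.46 log units; beyond the scatter).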

Compound 3, half-maximal inhibitory concentration: 4760 nM
Estimate against measurement, compound 3: 12-fold (1.08 log units) below; measured number above the stated range.
By their numbers in this assay, from the lowest: compound 2; then compound 3; then compound 1.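

In this assay the one-place change on the double-bonded ring carbon gives a 34-fold higher number from compound 2 to compound 3 (1.53 log units; beyond the scatter) and so shows that this position responds strongly to the group it carries, which the earlier pair, differing in more than one place, could not show. The count of heavy atoms does not set the number here: leaving (dimethylamino)methyl and the entering group both have 4 heavy atoms, no ring, no hydrogen-bond donor and no net charge, while the entering group adds an oxygen, a double bond outside aromatic rings and one more hydrogen-bond acceptor. No measurement available here bears on why the step is so large.

With a single exchange, the oxygen, the double bond and the loss of the (dimethylamino)methyl group cannot be told apart as the source of the step. On these data alone, whether the low number of compound 2 stays with other amines on the same carbon, such as a (diethylamino)methyl or a pyrrolidin-1-ylmethyl group, or falls with a plain ethyl chain of no nitrogen, remains open.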